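A few compounds are considered here, and "the series" means these few. Any claim that something is new, unique, unknown or untested is made for them only; others in the source may bear on it.

Compound 3 `CCCSc1nc(Cl)c2c(n1)N(Cc1ccccc1)C(C(=O)OCC)N2` gives 18500 nM in a functional assay on MGC-803 cells (Homo sapiens) for antiproliferative activity, read by MTT assay, with a stated time of 72 h (on this read-out higher numbers stand for weaker inhibition and lower numbers for stronger inhibition), and this number is one of the two figures seen among the compounds with a measured value. Compound 2 `CCCSc1nc(Cl)c2c(n1)N(Cc1ccccc1)C(C(=O)NCCC1=CCc3ccccc31)N2` gives 27000 nM in this assay, a result that sits within the scatter of the figure for compound 3. Compound 1 `CCCSc1nc(Cl)c2c(n1)N(Cc1ccccc1)C(C(=O)O)N2` shows only a limit in this assay, > 64000 nM, and is not a number. Among the measured compounds shown here, the one measured step, an at least 3.4-fold lower number from compound 1 to compound 3 (0.53 log units; beyond the scatter), moves the same carbonyl substituent and was at least modest. Compound 4 `CCCSc1nc(Cl)c2c(n1)N(Cc1ccccc1)C(C(=O)Nc1ccccc1)N2` differs from compound 3 by anilino in place of ethoxy on a carbonyl carbon. The measured step from compound 1 to compound 3 touches this position, and the values of compound 2 and compound 3 show that an amide and an ester at this carbonyl give figures within the scatter of each other, so a step from compound 3 to compound 4 within the scatter, a 1.2-fold lower number from compound 3 to compound 4 (0.09 log units; within the scatter), is expected. For compound 4 an estimate of 15000 nM is given, with a range from 5000 nM to 45000 nM.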

Compound 4, half-maximal inhibitory concentration: 58400 nM
Compound 4: the middle estimate sits 3.9-fold (0.59 log units) below what was measured; the measured number lies above the stated range.
By their numbers in this assay, from the lowest: compounds 3 and 2 (each within the scatter of the next); then compound 4. At a limit, above all of these: compound 1.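

In this assay, anilino in place of ethoxy on a carbonyl carbon gives a 3.2-fold higher number from compound 3 to compound 4 (0.50 log units; beyond the scatter), a modest step, so anilino does not match ethoxy here, even though the amide of compound 2 and the ester of compound 3 lie within the scatter of each other. An amide at this place does not settle the figure by itself, as there is a 2.2-fold higher number from compound 2 to compound 4 (0.34 log units; beyond the scatter) when the group on the amide-type nitrogen changes. The remaining step, an at least 1.0-fold lower number from compound 1 to compound 4 (0.03 log units; that floor lies within the scatter), cannot be read as a size. This is because compound 1 stands at a limit and not at a number: the limit of > 64000 nM in this assay, at which 1 of the 4 values shown sits.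

From the compounds shown here alone, it remains open how a longer chain on the ester oxygen would compare with ethoxy. Open too, going by these compounds, is whether a morpholine amide or a benzyl group on the amide-type nitrogen would fall nearer compound 2 or compound 4.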